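Aminophenyl isomers compared for cytotoxicity in two benzyl series

This account rests on a few compounds, and the source may have more. Where it says the series, first, only, none or still open, it means among the compounds named here.

Measured compounds:
compound 1, `Nc1cccc(/C=C2\SC(=O)N(Cc3cccc(Cl)c3)C2=O)c1`: 195000 nM
compound 2, `CC(C)(C)c1ccc(CN2C(=O)S/C(=C\c3ccc(N)cc3)C2=O)cc1`: 66000 nM
compound 3, `CC(C)(C)c1ccc(CN2C(=O)S/C(=C\c3cccc(N)c3)C2=O)cc1`: 165000 nM

Three compounds were tested in a functional assay on CCRF-CEM cells (Homo sapiens) for cytotoxicity, read by cell counting, with a stated time of 3 days; on this read-out lower numbers stand for stronger inhibition and higher numbers for weaker inhibition. Compound 3 carries the same core as compound 2, and the step 4-aminophenyl in place of 3-aminophenyl on a double-bonded chain carbon bound to a double-bonded ring carbon gives a 2.5-fold lower number from compound 3 to compound 2 (0.40 log units; beyond the scatter). Compound 1 carries a different core; the difference between the two cores is not broken down here. In this assay compound 1 gives 195000 nM, and compound 3 gives 165000 nM, so these two values show no separation worth noting, while compound 2 stands apart with 66000 nM.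

Compound 4, `Nc1ccc(/C=C2\SC(=O)N(Cc3cccc(Cl)c3)C2=O)cc1`, is not yet measured. It arises from compound 1 by 4-aminophenyl in place of 3-aminophenyl on a double-bonded chain carbon bound to a double-bonded ring carbon, the same change as that from compound 3 to compound 2. Because that earlier change produced a 2.5-fold lower number from compound 3 to compound 2 (0.40 log units; beyond the scatter), a step of similar size is expected for compound 4, namely a 2.5-fold lower number from compound 1 to compound 4 (0.40 log units; beyond the scatter). On that basis compound 4 is estimated at 78000 nM in this assay, with a likely range for compound 4 from 40000 nM to 160000 nM.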

Compound 4, half-maximal inhibitory concentration: 18000 nM
The estimate for compound 4 lay 4.3-fold (0.64 log units) above the measured number; measured number outside the range, below it.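

In this assay, 4-aminophenyl in place of 3-aminophenyl gives an 11-fold lower number from compound 1 to compound 4 (1.03 log units; beyond the scatter). The change kept its direction on moving from one core to the other, but not its size: the same change on two cores in this assay, a 2.5-fold lower number (0.40 log units; beyond the scatter) from compound 3 to compound 2 and an 11-fold lower number (1.03 log units; beyond the scatter) from compound 1 to compound 4, 4.3-fold (0.64 log units) apart, beyond the scatter of two such steps. Across these two pairs, 4-aminophenyl gives the lower number on both cores, yet the size of the step on one core did not fix its size on the other, and the pairs do not show which part of the cores accounts for the gap or whether the same holds across the series.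

The compounds shown leave open whether a step as large as that on the core of compound 1 would recur on further cores or remains confined to that one. They also leave open whether a hydroxyphenyl or dimethylaminophenyl group in place of the aminophenyl group would show the same order between its isomers on these two cores.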